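Saturating the Acyl Chain of Compound 3

This account rests on a few compounds, and the source may have more. Where it says the series, first, only, none or still open, it means among the compounds named here.

In a functional assay on HeLa cells (Homo sapiens) for cytotoxicity, read by resazurin assay, with a stated time of 24 h (on this read-out lower numbers stand for stronger inhibition and higher numbers for weaker inhibition), compound 1 `CC[C@H](C)CCC(=O)Nc1ccn([C@H]2CC[C@H](O[C@H]3O[C@H](C)[C@@H](N(C)C)[C@H](O)[C@H]3O)[C@@H](C)O2)c(=O)n1` gives > 64 ug/mL as a limit of the assay. Among the compounds with values here, compound 2 `CC(=O)C(C)Nc1ccc(C(=O)Nc2ccn([C@H]3CC[C@H](O[C@H]4O[C@H](C)[C@@H](N(C)C)[C@H](O)[C@H]4O)[C@@H](C)O3)c(=O)n2)cc1` reads 16 ug/mL and is the only compound here with a real number. Within the data shown here, the single measured step is an at least 4.0-fold lower number from compound 1 to compound 2 (0.60 log units; beyond the scatter) and it swaps 3-methylpentyl for 4-((1-acetylethyl)amino)phenyl, a different change from the one at issue. Compound 3 `CC(C)=CC(=O)Nc1ccn([C@H]2CC[C@H](O)[C@@H](C)O2)c(=O)n1` gives > 64 ug/mL as a limit too, the position described by the limit of > 64 ug/mL in this assay, at which 2 of the 3 values shown sit, in this series. Compound 4 `CC(C)CC(=O)Nc1ccn([C@H]2CC[C@H](O)[C@@H](C)O2)c(=O)n1` differs from it by isobutyl in place of 2-methylprop-1-en-1-yl on a carbonyl carbon with isobutyl in place of 2-methylprop-1-en-1-yl on a carbonyl carbon. Among the measured compounds shown here, no measured step covers this swap, so nothing beyond the scatter is expected. The expected change is a number no higher from compound 3 to compound 4 (the limit leaves the size open) and it remains an estimate. Compound 4 is estimated at 64 ug/mL with an expected range of 32 ug/mL to 128 ug/mL in this assay and will probably reach the limit again.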

Compound 4, half-maximal inhibitory concentration: > 64 ug/mL
Compound 4 gave a limit, no number; the forecaster's own chance of this, stated with the estimate: 80%; the middle value lies on the limit itself.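

Compound 3 and compound 4 both stop at a limit in this assay, so the step between them cannot be read. The compounds shown leave open whether isobutyl and 2-methylprop-1-en-1-yl on this carbonyl carbon differ at all.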